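Notes on the butyl to 2-methoxyphenyl exchange

A few compounds are considered here, and "the series" means these few. Any claim that something is new, unique, unknown or untested is made for them only; others in the source may bear on it.

Three compounds carry either a number or a limit in a functional assay on A549 cells (Homo sapiens) for antiproliferative activity, read by MTT assay, with a stated time of 72 h; a higher number here means a weaker inhibitor, a lower number a stronger inhibitor. Among the measured compounds shown here, compound 2 `CCCCc1cn(C[C@H](O)[C@H]2OC(=O)C(OCc3ccccc3)=C2OCc2ccccc2)nn1` gives 28600 nM in this assay, the only one of the three values that is a number. Compound 1 `O=C1O/C(=C\Cn2cc(-c3ccc(Br)cc3)nn2)C(OCc2ccccc2)=C1OCc1ccccc1` reaches only the limit of this assay, > 100000 nM. Compound 3 `CC(C)(C)OC(=O)N1CCN(C(=S)SCc2cn(C[C@H](O)[C@H]3OC(=O)C(OCc4ccccc4)=C3OCc3ccccc3)nn2)CC1` likewise stops at the limit, > 100000 nM. For the measured compounds named here, two of the three values shown thus sit at the limit of > 100000 nM in this assay, at which 2 of the 3 values shown sit, and compound 2 stands alone with a number; no pair of measured compounds differs in only one place, so no measured step is available.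

Compound 4 `COc1ccccc1-c1cn(C[C@H](O)[C@H]2OC(=O)C(OCc3ccccc3)=C2OCc2ccccc2)nn1` is not yet measured. It differs from compound 2 in 2-methoxyphenyl in place of butyl on an aromatic carbon. Compound 1 also carries a substituted phenyl on the five-membered aromatic ring with 3 nitrogen and sits at the limit, but its core differs from that of compound 2 in more than one place, so it shows only that such a pattern can go with a limit, not what the exchange alone does. The step from compound 2 to compound 4 is expected to be modest and toward weaker inhibition, a 1.4-fold higher number from compound 2 to compound 4 (0.15 log units; within the scatter), with little confidence in its direction. Compound 4 is expected to give 40000 nM in this assay, within 12000 nM to 100000 nM, with a real chance that only a limit is reported.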

Compound 4, half-maximal inhibitory concentration: > 100000 nM
Compound 4: no number, only a limit (the forecaster's own chance of this, stated with the estimate: 35%); middle value at least 2.5-fold (0.39 log units) from the limit.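

Among the compounds shown here, the exchange of butyl for 2-methoxyphenyl on an aromatic carbon of the five-membered aromatic ring with 3 nitrogen is the only single-place comparison available, and in this assay it reads as an at least 3.4-fold higher number from compound 2 to compound 4 (0.54 log units; beyond the scatter). For compound 4, > 100000 nM is a limit of this assay and not a number, so the step has a lower bound only. This position therefore does not tolerate every exchange on the shared core, and the measurable activity of compound 2 does not carry over to its 2-methoxyphenyl counterpart, which joins the values that offer no number: the limit of > 100000 nM in this assay, at which 3 of the 4 values shown sit.

One step cannot tell whether the ring of carbon only, the methoxy group with its hydrogen-bond acceptor, or the larger heavy-atom count of the entering group accounts for the change. An unsubstituted phenyl, a longer alkyl chain or a butyl chain ending in an amine at the same carbon would separate these readings, and would show whether any exchange here can give a lower number than compound 2 does.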